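A few compounds are considered here, and "the series" means these few. Any claim that something is new, unique, unknown or untested is made for them only; others in the source may bear on it.

Compound 2 (`Nc1nc(NCc2ccc(OCCCCC(=O)NO)cc2)nc2nc(-c3ccco3)nn12`) has no number to stand on: in a functional assay on MC-38 cells (Mus musculus) for antiproliferative activity, read by CCK-8 assay, with a stated time of 72 h (on this read-out lower numbers stand for stronger inhibition of growth and higher numbers for weaker inhibition of growth), compound 2 is reported as "not determined" (no result reported). Compound 1 (`Nc1nc(NCc2ccc(C(=O)NO)cc2)nc2nc(-c3ccco3)nn12`), which carries the same core, is likewise reported as "not determined" (no result reported). Compound 3 (`Nc1nc(NCCCc2ccc(C(=O)NO)cc2)nc2nc(-c3ccco3)nn12`) gives > 100000 nM, and this is a limit of the assay, not a number. Among the measured compounds shown here, the only evidence so far is therefore (the limit of > 100000 nM in this assay, at which 1 of the 3 values shown sits).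

Compound 4 (`Nc1ccccc1NC(=O)c1ccc(CNc2nc(N)n3nc(-c4ccco4)nc3n2)cc1`) has not yet been measured. The structural change is (2-aminophenyl)carbamoyl in place of 4-(hydroxycarbamoyl)butoxy on an aromatic carbon. In words, (2-aminophenyl)carbamoyl comes in place of 4-(hydroxycarbamoyl)butoxy on an aromatic carbon, para to a large group.

For the measured compounds named here, no pair of measured compounds shows what such a swap does, and compound 2 offers no number to start from. Going by the values given here, the sole guide is compound 3 at > 100000 nM, again only a limit. Weak inhibition of growth is therefore expected in this assay, with no large step in either direction. For compound 4 the estimated value is 50000 nM, with an expected range of 10000 nM to 100000 nM.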

Compound 4, concentration for 50% growth inhibition: 14100 nM
For compound 4 the middle estimate is 3.5-fold (0.55 log units) above the measured one; the range from low to high includes it.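

Compound 2 has no number in this assay, so the swap that leads to compound 4, at 14100 nM, cannot be read as a step. The compounds shown leave open how (2-aminophenyl)carbamoyl compares with 4-(hydroxycarbamoyl)butoxy for inhibition of growth.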